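The source may report more compounds than this note shows. Statements on the series, on what has been measured and on what is new or still open speak of the compounds shown alone.

Compound 1 `COc1cccc(S(=O)(=O)/C=C/c2ncccc2F)c1` gives 444 nM in an assay on U2OS cells for activation of nuclear factor erythroid 2-related factor 2 (Homo sapiens), read by chemiluminescence, with a stated time of 6 h; a lower number here means that less compound is needed, a higher number that more compound is needed for the effect. Compound 2 `COc1cccc(S(=O)(=O)/C=C/c2ncccc2Cl)c1` carries the change chloro in place of fluoro on an aromatic carbon and gives 98 nM in this assay; the step is a 4.5-fold lower number from compound 1 to compound 2 (0.66 log units; beyond the scatter). Compound 3 `COc1ccc(S(=O)(=O)/C=C/c2ncccc2F)cc1` gives 1080 nM in this assay, the highest number of the three; the difference between its core and the core of compound 1 is not broken down here. Compound 4 `COc1ccc(S(=O)(=O)/C=C/c2ncccc2Cl)cc1` has not been measured; from compound 3 it carries chloro in place of fluoro on an aromatic carbon, the same change as from compound 1 to compound 2. Because the step of a 4.5-fold lower number from compound 1 to compound 2 (0.66 log units; beyond the scatter) was clear, the same change on compound 3 is expected to give a similar step, a 4.5-fold lower number from compound 3 to compound 4 (0.65 log units; beyond the scatter), in this assay. Compound 4 is therefore estimated at 240 nM in this assay, most likely between 110 nM and 550 nM.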

Compound 4, half-maximal effective concentration: 347 nM
Compound 4: middle estimate off by 1.4-fold (0.16 log units), on the low side; low and high end bracket the measured number.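

In this assay the change of chloro in place of fluoro on an aromatic carbon gives a 3.1-fold lower number from compound 3 to compound 4 (0.49 log units; beyond the scatter). The step carries over from the core of compound 1 to the core of compound 3, and the two steps cannot be told apart: the same change on two cores in this assay, a 4.5-fold lower number (0.66 log units; beyond the scatter) from compound 1 to compound 2 and a 3.1-fold lower number (0.49 log units; beyond the scatter) from compound 3 to compound 4, 1.5-fold (0.16 log units) apart, within the scatter of two such steps. This rests on two pairs of compounds only, so it does not show that the step would hold on any other core, nor does it show why chloro gives the lower number.

The compounds shown hold only fluoro and chloro on that aromatic carbon, so a bromo, a methyl or a nitrile there remains open. Also open, going by these compounds, is whether the step persists with an amine or a carboxylic acid elsewhere on the molecule.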